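This account rests on a few compounds, and the source may have more. Where it says the series, first, only, none or still open, it means among the compounds named here.

Working notes on the series, read in a functional assay on CEM-DNR-bulk cells (Homo sapiens), read by MTT assay, with a stated time of 72 h; a lower number here means a stronger inhibitor, a higher number a weaker inhibitor. Compound 1 (`O=c1[nH]cnc2c1c(-c1cc3ccccc3o1)cn2[C@@H]1O[C@H](CO)[C@@H](O)[C@H]1O`) gives > 20000 nM, which is a limit and not a number. Compound 2 (`Nc1nc(N)c2c(-c3cccs3)cn([C@@H]3O[C@H](CO)[C@@H](O)[C@H]3O)c2n1`) gives > 20000 nM, again a limit. Compound 3 (`Cc1nc(N)c2c(-c3cccs3)cn([C@@H]3O[C@H](CO)[C@@H](O)[C@H]3O)c2n1`) gives > 20000 nM, also a limit, so it has no numeric position in the series. The evidence so far amounts to the limit of > 20000 nM in this assay, at which 3 of the 3 values shown sit.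

Compound 4 (`C#Cc1cn([C@@H]2O[C@H](CO)[C@@H](O)[C@H]2O)c2nc(C)nc(N)c12`) carries ethynyl in place of thiophen-2-yl on an aromatic carbon of the five-membered aromatic ring, and the counted difference is ethynyl in place of thiophen-2-yl on an aromatic carbon. For the measured compounds named here, the one measured step is a step that the two limits leave unreadable from compound 2 to compound 3. That step concerns methyl in place of amino, and it gives no size to carry over to the ethynyl change. Going by the values given here, no measured step involves the group that changes here, so any expectation is weakly founded. Compound 4 is expected to stay near the limit reached by compound 3, and a reading is more likely than not to be a limit again. Any number that does appear can only lie on the stronger side. Among the compounds with values here, the expected change is an at least 2.0-fold lower number from compound 3 to compound 4 (0.30 log units; that floor lies within the scatter), an estimate with no measured step to size it. The estimate for compound 4 is 10000 nM, with an expected range from 1000 nM to 20000 nM.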

Compound 4, half-maximal inhibitory concentration: 12600 nM
Compound 4: middle estimate off by 1.3-fold (0.10 log units), on the low side; low and high end bracket the measured number.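

In this assay, for the compounds shown here, the position on the five-membered aromatic ring, two ring bonds from the ring nitrogen, gives its first numeric reading: with ethynyl in place of thiophen-2-yl, compound 4 stands at 12600 nM as the only value that is a number. The step is an at least 1.5-fold lower number from compound 3 to compound 4 (0.20 log units; that floor lies within the scatter) and is bounded on one side only, so this pair does not establish a change beyond the scatter, though a larger one remains possible. The other compounds still give no number, and the series remains dominated by the assay limit: the limit of > 20000 nM in this assay, at which 3 of the 4 values shown sit.

As far as these compounds go, whether ethynyl still gives a numeric reading with amino in place of methyl on the shared core, as compound 2 carries, remains open. Also open, from the compounds shown here alone, is how this position reads with a longer alkyne chain, an amine or a carboxylic acid, and whether any such group moves the number clearly beyond the scatter.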